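Ethoxy in place of nitro: expected return of activity

The source may hold more compounds than are shown below. What is called first, only, known or untested is meant among the compounds shown, and "the series" means these compounds.

Measured in a functional assay on MCF7 cells (Homo sapiens) for cytotoxicity; on this read-out higher numbers stand for weaker inhibition and lower numbers for stronger inhibition:
- Compound 1 `Cc1ccc2nc(NC(=O)CCCCC(=O)NO)sc2c1`: 4.27 ug/mL
- Compound 2 `O=C(CCCCC(=O)Nc1nc2ccc([N+](=O)[O-])cc2s1)NO`: > 30 ug/mL

Compound 2 stands at a limit of this assay, > 30 ug/mL, and has no number. Compound 3 `CCOc1ccc2nc(NC(=O)CCCCC(=O)NO)sc2c1` carries ethoxy in place of nitro on an aromatic carbon. Among the compounds with values here, the one measured step bearing on this change is an at least 7.0-fold higher number from compound 1 to compound 2 (0.84 log units; beyond the scatter), with nitro in place of methyl on an aromatic carbon. Losing the nitro is therefore expected to bring a step of at least that size towards lower numbers in this assay, back towards the 4.27 ug/mL of compound 1. The expected change is an at least 6.6-fold lower number from compound 2 to compound 3 (0.82 log units; beyond the scatter). For compound 3 the estimated value is 4.5 ug/mL, with an expected range of 1.5 ug/mL to 15 ug/mL.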

Compound 3, half-maximal inhibitory concentration: 8.72 ug/mL
The estimate for compound 3 lay 1.9-fold (0.29 log units) below the measured number; measured number inside the range.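

In this assay, ethoxy in place of nitro gives an at least 3.4-fold lower number from compound 2 to compound 3 (0.53 log units; beyond the scatter), so a measurable value returns at this position. Ethoxy in place of methyl gives a 2.0-fold higher number from compound 1 to compound 3 (0.31 log units; beyond the scatter), so ethoxy does not fully match methyl here. Compound 2 supplies only a limit, so the size of the nitro-to-ethoxy step is a bound and not a measured difference: the limit of > 30 ug/mL in this assay, at which 1 of the 3 values shown sits.

From the compounds shown here alone, whether an amine or a carboxylic acid at this position would sit with methyl and ethoxy or with nitro remains open. Also open, going by these compounds, is whether an alkoxy chain longer than ethoxy would move the number further in the same direction.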